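Lengthening the Chain of Compound 1

The source may report more compounds than this note shows. Statements on the series, on what has been measured and on what is new or still open speak of the compounds shown alone.

- compound 1 `CN1CCN(CCCCn2c3c(c4ccccc42)C(=O)c2c[n+]([O-])c4ccccc4c2C3=O)CC1`: 110 nM
- compound 2 `CC1(C)O[C@@H](CO)[C@H](Cn2cc(Cn3c4c(c5ccccc53)C(=O)c3c[n+]([O-])c5ccccc5c3C4=O)nn2)O1`: 680 nM

Both compounds were measured in a functional assay on MDA-MB-231 cells (Homo sapiens) for cytotoxicity, read by MTT assay, with a stated time of 72 h; a lower number here means a stronger inhibitor, a higher number a weaker inhibitor. Compound 1 holds the lower number of the two, which makes it the stronger inhibitor of this pair. Compound 2 gives the higher number, and the gap between them lies beyond the usual scatter of repeated measurements. The two differ in more than one place, so no measured single change is available as a guide.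

The next compound to be measured is compound 3 `CN1CCN(CCCCCCn2c3c(c4ccccc42)C(=O)c2c[n+]([O-])c4ccccc4c2C3=O)CC1`, which keeps the core of compound 1 and differs in one place: 2-(4-methylpiperazin-1-yl)ethyl in place of 4-methylpiperazin-1-yl on a saturated chain carbon, four bonds along the chain from an aromatic nitrogen. It carries 2-(4-methylpiperazin-1-yl)ethyl in place of 4-methylpiperazin-1-yl on a saturated chain carbon, four bonds along the chain from an aromatic nitrogen.

With no measured chain change to draw on, only a small move towards a higher number is expected, probably none beyond the scatter. The expected step is a 1.5-fold higher number from compound 1 to compound 3 (0.16 log units; within the scatter). In this assay the estimated value for compound 3 is 160 nM, with an expected range of 55 nM to 470 nM.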

Compound 3, half-maximal inhibitory concentration: 2400 nM
Compound 3: the middle estimate sits 15-fold (1.18 log units) below what was measured; the measured number lies above the stated range.
By their numbers in this assay, from the lowest: compound 1; then compound 2; then compound 3.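

The chain on the aromatic nitrogen turns out to be a sensitive place in this assay, something the earlier pair could not show, since those two compounds differ in more than one place. Putting 2-(4-methylpiperazin-1-yl)ethyl in place of 4-methylpiperazin-1-yl on the saturated chain carbon gives a 22-fold higher number from compound 1 to compound 3 (1.34 log units; beyond the scatter) and so a large loss, although the methylpiperazine ring and the counts of hydrogen-bond donors and acceptors stay the same. Within these compounds, then, the length of the chain alone separates a strong inhibitor from a much weaker one, and nothing shown here accounts for the size of this step.

The compounds shown leave open how the numbers run with chain length, since a shorter propyl chain or a pentyl chain of intermediate length could show whether the loss grows steadily or appears abruptly. They also leave open whether the same step would follow if a morpholine or a simple dimethylamine stood in place of 4-methylpiperazin-1-yl, and so whether it belongs to the chain alone or to the chain together with this amine.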